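The source may hold more compounds than are shown below. What is called first, only, known or untested is meant among the compounds shown, and "the series" means these compounds.

Compound 1 `Fc1ccc(-c2[nH]c(SCc3ccccc3)nc2-c2ccncc2)cc1`: 300 nM
Compound 2 `C[S+]([O-])c1cc(CSc2nc(-c3ccc(F)cc3)c(-c3ccncc3)[nH]2)ccc1O`: 2300 nM

In a functional assay (Homo sapiens) for inhibition (on this read-out higher numbers stand for weaker inhibition and lower numbers for stronger inhibition), compound 1 gives 300 nM, the lower of the two numbers and so the stronger inhibition, while compound 2 gives 2300 nM. Compound 3 `Fc1ccc(-c2[nH]c(CCc3ccccc3)nc2-c2ccncc2)cc1` differs from compound 1 at one place: phenethyl in place of benzylsulfanyl on an aromatic carbon. Phenethyl stands in place of benzylsulfanyl on an aromatic carbon. Within the data shown here, no measured pair shows this change, so the expectation is uncertain: a small move toward a higher number, perhaps none beyond the scatter. The expected size is a 1.7-fold higher number from compound 1 to compound 3 (0.22 log units; within the scatter). For compound 3, the estimated value is 500 nM, with an expected range of 150 nM to 1800 nM.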

Compound 3, half-maximal inhibitory concentration: 140 nM
Compound 3: the middle estimate sits 3.6-fold (0.55 log units) above what was measured, outside the stated range (below it).
By their numbers in this assay, from the lowest: compound 3; then compound 1; then compound 2.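

In this assay, phenethyl in place of benzylsulfanyl gives a 2.1-fold lower number from compound 1 to compound 3 (0.33 log units; beyond the scatter) on this aromatic carbon between two ring nitrogen atoms. So the sulfur of benzylsulfanyl is not required for inhibition here: a chain of carbon alone serves, and the gain is modest. No evidence at hand explains this gain. Going by these compounds, whether a longer chain such as 3-phenylpropyl would lower the number further remains open. So does whether an amine linking the benzyl group to the shared core would match phenethyl.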